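Thiazole for Cyanophenyl: Expected Efficacy of Compound 3

This account rests on a few compounds, and the source may have more. Where it says the series, first, only, none or still open, it means among the compounds named here.

Compound 1, `O/N=C(/CCN1CCN(c2ccccn2)CC1)c1cc(F)cc(F)c1`: 70%
Compound 2, `CCO/N=C(\CCN1CCN(c2ccccc2C#N)CC1)c1ccccc1`: 82%

Among the measured compounds shown here, in a functional assay on HEK293 cells with D(4) dopamine receptor (Homo sapiens) as the target, read by FLIPR (on this read-out lower numbers stand for smaller maximal responses and higher numbers for larger maximal responses), compound 2 gives 82%, the higher of the two numbers measured so far. Compound 1 gives 70%, a gap that lies beyond the usual scatter. Compound 3, `CCO/N=C(\CCN1CCN(c2nccs2)CC1)c1ccccc1`, differs from compound 2 in one place: 1,3-thiazol-2-yl in place of 2-cyanophenyl on an amine nitrogen in a ring. For the measured compounds named here, no measured pair shows a change of this kind, so the expectation rests on compound 2 alone. Compound 3 is expected to move only slightly, a number 6 percentage points lower from compound 2 to compound 3 (within the scatter), a step that would sit within the scatter. Compound 3 is therefore estimated at 76%, with a range from 56% to 96%.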

Compound 3, largest response reached (reported as efficacy), in percent of the reference or control that the assay uses: 72%
The estimate for compound 3 lay 4 percentage points above the measured number; low and high end bracket the measured number.
By their numbers in this assay, from the lowest: compounds 1, 3 and 2 (each within the scatter of the next, the first and the last beyond it).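

In this assay, among the compounds shown here, this is the first step read at this place, on an amine nitrogen in a ring: a number 10 percentage points lower from compound 2 to compound 3 (within the scatter). So 1,3-thiazol-2-yl, a five-membered aromatic ring with 5 heavy atoms, can replace 2-cyanophenyl, a six-membered aromatic ring of carbon only with 8 heavy atoms, with no step beyond the scatter. No measurement at hand bears on why this step has the size it has. Going by these compounds, it remains open how a 1,3-oxazol-2-yl or an unsubstituted phenyl group would read at this place. Also open, on these data alone, is whether the step would hold on the core of compound 1.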